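A Sulfonyl for a Carbonyl on the Shared Core

This account rests on a few compounds, and the source may have more. Where it says the series, first, only, none or still open, it means among the compounds named here.

Compound 2 `CN(C)c1ccc(C2CC(c3ccc(-n4ccnc4)cc3)=NN2C(=O)c2ccc(C(F)(F)F)cc2)cc1` stands highest of the two numbers measured in a functional assay on HCC1806 cells (Homo sapiens) for inhibition, read by sulforhodamine B assay, tested at 10 uM (on this read-out higher numbers stand for more inhibition at the one concentration tested (going by the name of the read-out) and lower numbers for less inhibition), where compound 2 gives 28%. Going by the values given here, its nearest neighbour is compound 1 `CN(C)c1ccc(C2CC(c3ccc(-n4ccnc4)cc3)=NN2C(=O)CCCl)cc1`, which in this assay gives -5.2%; the only measured step, a number 33.2 percentage points higher from compound 1 to compound 2 (beyond the scatter), lies between them. Compound 3 `CN(C)c1ccc(C2CC(c3ccc(-n4ccnc4)cc3)=NN2S(=O)(=O)c2ccc(C#N)cc2)cc1` is not yet measured. It differs from compound 2 in one place: (4-cyanophenyl)sulfonyl in place of (4-(trifluoromethyl)phenyl)carbonyl on an amine nitrogen in a ring. The step from compound 1 to compound 2 bears on this only in that it also exchanged the group on the amine nitrogen in a ring of the shared core, and that step was large. Among the compounds with values here, no measured pair shows how an aromatic group joined through a sulfonyl compares with one joined through a carbonyl. The expected step is therefore a number 3 percentage points lower from compound 2 to compound 3 (within the scatter) in this assay, close to none beyond the scatter, with wide uncertainty. Compound 3 is thus estimated at 25%, between 0% and 55%.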

Compound 3, a percentage reported as inhibition, at one concentration (the size of the read-out at that concentration, not a potency): 4.7%
The estimate for compound 3 lay 20.3 percentage points above the measured number, within the range that was stated.
By their numbers in this assay, from the lowest: compounds 1 and 3 (each within the scatter of the next); then compound 2.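

In this assay, going by these compounds alone, this is the first measured exchange of an aromatic group joined through a carbonyl for one joined through a sulfonyl on the amine nitrogen in a ring, and it gives a number 23.3 percentage points lower from compound 2 to compound 3 (beyond the scatter). An aromatic ring at this position therefore does not by itself bring the number of compound 2, as compound 3 also carries one. The (4-cyanophenyl)sulfonyl and (2-chloroethyl)carbonyl groups cannot be told apart here, with a number 9.9 percentage points higher from compound 1 to compound 3 (within the scatter), and nothing available accounts for the lower number of compound 3.

On these data alone, the step changes the link and the group on the aromatic ring together, so the share of each stays open. Also open, as far as these compounds go, is how a carboxylic acid or an amine in place of the nitrile would read on the sulfonyl series.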